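This account rests on a few compounds, and the source may have more. Where it says the series, first, only, none or still open, it means among the compounds named here.

Compounds measured in an ADME assay on HUVEC cells (Homo sapiens) for inhibition, read by MTT assay, with a stated time of 48 h; a lower number here means a stronger inhibitor, a higher number a weaker inhibitor:
compound 1 `COc1ccccc1-c1csc(N/N=C/c2cc(OC)c(OC)c(Br)c2Br)n1` — > 100000 nM
compound 2 `COc1cc(/C=N/Nc2nc(-c3ccc(Br)cc3)cs2)cc(Br)c1OC` — > 100000 nM
compound 3 `COc1cc(/C=N/Nc2nc(-c3ccc(F)c(F)c3)cs2)c(Br)c(Br)c1OC` — 54700 nM.

The value of compound 1 is a limit of this assay, not a number. The value of compound 2 is likewise a limit. Within the data shown here, compound 3 is thus the only compound of the three with a measured number, and the others sit at the limit of > 100000 nM in this assay, at which 2 of the 3 values shown sit. Among the measured compounds shown here, the one step computed between measured compounds, an at least 1.8-fold lower number from compound 1 to compound 3 (0.26 log units; that floor lies within the scatter), is a floor that lies within the usual scatter, so it says little about direction.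

Compound 4 `COc1cc(/C=N/Nc2nc(-c3ccc(Br)cc3)cs2)c(Br)c(Br)c1OC` has not yet been measured. It differs from compound 3 in one place: 4-bromophenyl in place of 3,4-difluorophenyl on an aromatic carbon. For the measured compounds named here, no measured step mirrors this exact change. Compound 2, which also carries a 4-bromophenyl, gives a limit; compound 3 carries the 3,4-difluorophenyl and gives a number. On this basis the account expects compound 4 to be a somewhat weaker inhibitor than compound 3, a step of a 1.6-fold higher number from compound 3 to compound 4 (0.19 log units; within the scatter), with a real chance that only a limit is reported. The estimate for compound 4 in this assay is 85000 nM, within 35000 nM to 200000 nM.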

Compound 4, half-maximal inhibitory concentration: > 100000 nM
Compound 4 gave a limit, no number; the forecaster's own chance of this, stated with the estimate: 50%; middle value at least 1.1-fold (0.07 log units) away from the limit.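

In this assay, 4-bromophenyl in place of 3,4-difluorophenyl, on the aromatic carbon next to the ring nitrogen, gives an at least 1.8-fold higher number from compound 3 to compound 4 (0.26 log units; that floor lies within the scatter), so this second step at the position again yields only a floor and does not settle a direction. The steps to compound 4 from compound 1 and from compound 2 cannot be read, as both ends of each are limits, and so the added bromo of compound 4 shows nothing that can be sized. Among the four compounds, only compound 3 carries a number, and the rest stand at one limit: the limit of > 100000 nM in this assay, at which 3 of the 4 values shown sit.

Going by these compounds, how far compound 4 lies past its limit stays open. Also open, on these data alone, is whether an amine or a carboxylic acid on the phenyl ring at this position would give a number in this assay.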